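The source may hold more compounds than are shown below. What is called first, only, known or untested is meant among the compounds shown, and "the series" means these compounds.

Measured compounds:
compound 1 `CC1=C(C(=O)CC(C)C)C(c2ccoc2)NC(=O)N1`, 18%
compound 2 `CC1=C(c2ncc(C)o2)C(c2ccoc2)NC(=O)N1`, 1%

In an assay on membranes from HeLa cells for displacement of a labelled ligand from adenosine receptor A3 (Homo sapiens), read by scintillation counting, with a stated time of 180 min, tested at 1 uM (on this read-out lower numbers stand for less inhibition and higher numbers for more inhibition at the one concentration tested (going by the name of the read-out)), compound 1 stands highest of the two numbers; the nearest is compound 2, reached by a number 17 percentage points lower from compound 1 to compound 2 (beyond the scatter). Compound 3 `CC1=C(C(=O)OC2CCCCC2)C(c2ccoc2)NC(=O)N1` is not yet measured. It differs from compound 1 by cyclohexyloxy in place of isobutyl on a carbonyl carbon. Among the measured compounds shown here, the single measured step exchanges the whole carbonyl unit for a ring and so does not bear directly on a change that keeps the carbonyl carbon. For the measured compounds named here, with no relevant step, the expected change is a number 2 percentage points higher from compound 1 to compound 3 (within the scatter), a step not expected to exceed the scatter. Compound 3 is estimated at 20%, within 0% to 45%.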

Compound 3, a percentage reported as inhibition, at one concentration (the size of the read-out at that concentration, not a potency): 1%
Beside the measured number, compound 3's estimate is 19 percentage points above it; the measured number falls inside the stated range.
By their numbers in this assay, from the lowest: compounds 2 and 3 (each within the scatter of the next); then compound 1.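

In this assay, keeping the carbonyl carbon and putting cyclohexyloxy in place of isobutyl gives a number 17 percentage points lower from compound 1 to compound 3 (beyond the scatter). This position therefore responds to a change in the group on the carbonyl carbon alone, which the earlier exchange of the whole carbonyl unit could not show. No available evidence accounts for this step.

The change brings in the oxygen and the six-membered ring together, leaving their separate contributions open. Open too, from the compounds shown here alone, is how a cyclohexylamino group or a methoxy group on the same carbonyl carbon would read.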